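Thiadiazole for Fluorophenyl on Two Hydrazone Cores

The source may hold more compounds than are shown below. What is called first, only, known or untested is meant among the compounds shown, and "the series" means these compounds.

Measured compounds:
compound 1 `O=C(N/N=C/C1=Cc2ccccc2OC1c1ccccc1)c1ccc(F)cc1` — 30900 nM
compound 2 `Cc1nnsc1C(=O)N/N=C/C1=Cc2ccccc2OC1c1ccccc1` — 30200 nM
compound 3 `O=C(N/N=C/c1c(Cl)c2ccccc2oc1=O)c1ccc(F)cc1` — 26200 nM

Three compounds have been run in a toxicity assay on HEK-293T cells (Homo sapiens) for cytotoxicity, read by MTT assay, with a stated time of 72 h; a lower number here means a stronger inhibitor, a higher number a weaker inhibitor. In this assay compound 1 gives 30900 nM, compound 2 gives 30200 nM and compound 3 gives 26200 nM; all three values lie within the scatter of one another, so no order among them can be read.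

Compound 1 and compound 2 share a core and differ only by 4-methyl-1,2,3-thiadiazol-5-yl in place of 4-fluorophenyl on a carbonyl carbon. That change produced a 1.0-fold lower number from compound 1 to compound 2 (0.01 log units; within the scatter). The core of compound 3 is a different one; how it differs from the core of compound 1 is not broken down here.

Compound 4 `Cc1nnsc1C(=O)N/N=C/c1c(Cl)c2ccccc2oc1=O` is compound 3 carrying the same change, (4-methyl-1,2,3-thiadiazol-5-yl in place of 4-fluorophenyl on a carbonyl carbon), at the same place as before. Among the measured compounds shown here, since the one earlier instance of this change gave a 1.0-fold lower number from compound 1 to compound 2 (0.01 log units; within the scatter), compound 4 is expected to show a 1.0-fold lower number from compound 3 to compound 4 (0.00 log units; within the scatter). Compound 4 is therefore estimated at 26000 nM in this assay, most likely between 13000 nM and 52000 nM.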

Compound 4, half-maximal inhibitory concentration: 30200 nM
For compound 4 the middle estimate is 1.2-fold (0.07 log units) below the measured one; the range from low to high includes it.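

In this assay, putting 4-methyl-1,2,3-thiadiazol-5-yl in place of 4-fluorophenyl on the carbonyl carbon of the core of compound 3 gave a 1.2-fold higher number from compound 3 to compound 4 (0.06 log units; within the scatter). Set beside the earlier instance, the two steps cannot be told apart: the same change on two cores in this assay, a 1.0-fold lower number (0.01 log units; within the scatter) from compound 1 to compound 2 and a 1.2-fold higher number (0.06 log units; within the scatter) from compound 3 to compound 4, 1.2-fold (0.07 log units) apart, within the scatter of two such steps. Among the compounds shown here, on these two cores, then, the swap leaves the reading indistinguishable from the scatter each time, but this rests on only two pairs and shows no real effect being carried from one core to the other, so it does not establish that the change would behave alike on any further core.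

The compounds shown leave open whether an amine or a carboxylic acid on the same carbonyl carbon, in place of either ring, would give a step beyond the scatter. They also leave open what a simple methyl group there would do on either core.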